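Propyl in place of fluoro on the shared core

The source may report more compounds than this note shows. Statements on the series, on what has been measured and on what is new or still open speak of the compounds shown alone.

Measured so far in a functional assay for inhibition of sodium/hydrogen exchanger (Oryctolagus cuniculus); on this read-out higher numbers stand for weaker inhibition and lower numbers for stronger inhibition:
compound 1 `Cc1cc(F)c(S(C)(=O)=O)cc1C(=O)N=C(N)N` gives 44 nM
compound 2 `CCc1cc(Cl)c(S(C)(=O)=O)cc1C(=O)N=C(N)N` gives 63 nM
compound 3 `CS(=O)(=O)c1cc(C(=O)N=C(N)N)c(F)cc1F` gives 630 nM

Compound 1 holds the lowest of the three numbers in this assay. Compound 2 sits close to it, the two values lying within the scatter of each other, so nothing separates them. Compound 3 is the clear outlier: a 14-fold higher number from compound 1 to compound 3 (1.16 log units; beyond the scatter).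

The next step takes compound 1 to compound 4 `CCCc1cc(C)c(C(=O)N=C(N)N)cc1S(C)(=O)=O`. The change is propyl in place of fluoro on an aromatic carbon, the site being ortho to a methylsulfonyl group, meta to a methyl group and para to a group of 6 heavy atoms. Going by the values given here, no measured pair swaps a group at this site; the one step that exchanges fluoro against an alkyl group is the one from compound 1 to compound 3, which went the other way and at the other ring position. Compound 2, carrying chloro here beside ethyl, gives a number within the scatter of compound 1. On that basis the fluoro position looks tolerant, and a propyl chain is not expected to move the number far; the estimate for compound 4 is 60 nM with a range of 20 nM to 200 nM, corresponding to an expected step of a 1.4-fold higher number from compound 1 to compound 4 (0.13 log units; within the scatter).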

Compound 4, half-maximal inhibitory concentration: 5.7 nM
The estimate for compound 4 lay 11-fold (1.02 log units) above the measured number; measured number below the stated range.
By their numbers in this assay, from the lowest: compound 4; then compounds 1 and 2 (each within the scatter of the next); then compound 3.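

Fluoro on the aromatic carbon ortho to a methylsulfonyl group and para to a group of 6 heavy atoms can be replaced by a larger alkyl chain without loss in this assay. The step to propyl gives a 7.7-fold lower number from compound 1 to compound 4 (0.89 log units; beyond the scatter), so this site affects the read-out and its substituent can lower the number beyond the scatter. Compound 4 is the only compound shown with an alkyl chain at this site, and no measured property among these data accounts for the lower number.

A single propyl chain does not show whether the number keeps falling as the chain grows, so a butyl chain or a longer one remains to be compared. As far as these compounds go, it is also open whether this site would accept an amine or a carboxylic acid.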